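This account rests on a few compounds, and the source may have more. Where it says the series, first, only, none or still open, it means among the compounds named here.

Measured in a functional assay on HeLa cells (Homo sapiens) for antiproliferative activity, read by MTT assay, with a stated time of 48 h; a higher number here means a weaker inhibitor, a lower number a stronger inhibitor:
- compound 1 `COc1cc(C(=O)/C=C/c2c[nH]c3ccccc23)cc([N+](=O)[O-])c1OC` gives 1350 nM
- compound 2 `COc1cc(C(=O)/C=C/c2c[nH]c3ccccc23)cc(SC)c1OC` gives 159 nM
- compound 3 `COc1cc(C(=O)/C=C/c2cn(C)c3ccccc23)cc(N)c1OC` gives 668 nM

Compound 3 (668 nM) takes the middle place among these numbers, with compound 2 (159 nM) lower and compound 1 (1350 nM) higher.

The next compound to consider is compound 4 `COc1cc(C(=O)/C=C/c2c[nH]c3ccccc23)cc(N)c1OC`, which has not yet been measured. It differs from compound 3 at one place, with hydrogen in place of methyl on an aromatic nitrogen.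

Going by the values given here, only one measured step is available: an 8.5-fold lower number from compound 1 to compound 2 (0.93 log units; beyond the scatter), with methylsulfanyl in place of nitro on an aromatic carbon. It shows that a single swap can move the number in this assay, but it happens elsewhere on the molecule and gives no size for a change on the nitrogen. Compound 1 and compound 2 already carry hydrogen on that nitrogen, but they also differ from compound 3 on that aromatic carbon, so their values cannot isolate the effect of the methyl.

Among the compounds with values here, with no measured step at this nitrogen, no clear shift in either direction is expected, and the uncertainty remains wide. The expected outcome is a 1.1-fold lower number from compound 3 to compound 4 (0.05 log units; within the scatter), an estimate and not a measurement. For compound 4 the estimated value is 600 nM, with an expected range from 200 nM to 2000 nM.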

Compound 4, half-maximal inhibitory concentration: 529 nM
Beside the measured number, compound 4's estimate is 1.1-fold (0.05 log units) above it, within the range that was stated.
By their numbers in this assay, from the lowest: compound 2; then compounds 4 and 3 (each within the scatter of the next); then compound 1.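

In this assay, hydrogen in place of methyl on the aromatic nitrogen gives a 1.3-fold lower number from compound 3 to compound 4 (0.10 log units; within the scatter) and so does not clearly separate the two compounds, at least with amino on the aromatic carbon. Compound 4 also carries hydrogen on that nitrogen, like compound 1 and compound 2, so the group on the aromatic carbon can now be compared on its own: there is a 3.3-fold higher number from compound 2 to compound 4 (0.52 log units; beyond the scatter) and also a 2.6-fold lower number from compound 1 to compound 4 (0.41 log units; beyond the scatter) and both steps lie beyond the scatter, which places the amino compound in the middle of this set of three. No available measurement accounts for the size or direction of these steps.

Going by these compounds alone, the only pair that isolates the nitrogen carries amino on the aromatic carbon, so it remains open whether the same swap would stay as small with methylsulfanyl or nitro there. Also open, on these data alone, is where a longer chain such as propyl on the nitrogen, or a hydroxyl or carboxylic acid on the aromatic carbon, would fall in this assay relative to these compounds.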